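Swapping nitro for trifluoromethyl in a close series

The source may report more compounds than this note shows. Statements on the series, on what has been measured and on what is new or still open speak of the compounds shown alone.

Values in an ADME assay on L02 cells (Homo sapiens) for cytotoxicity, read by MTT assay, with a stated time of 24 h; on this read-out higher numbers stand for weaker inhibition and lower numbers for stronger inhibition:
- compound 1 `O=C1/C(=C/c2cccnc2)CN(S(=O)(=O)c2ccc(C(F)(F)F)cc2)C/C1=C\c1ccccc1F` gives 11300 nM
- compound 2 `O=C1/C(=C/c2cccnc2)CN(S(=O)(=O)c2ccccc2)C/C1=C\c1ccccc1C(F)(F)F` gives 12500 nM
- compound 3 `O=C1/C(=C/c2cccnc2)CN(S(=O)(=O)c2ccc([N+](=O)[O-])cc2)C/C1=C\c1ccccc1C(F)(F)F` gives 15700 nM

The three measured compounds sit close together. Compound 3, at 15700 nM, lies within the scatter of both compound 2 and compound 1, so the numbers do not separate them.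

The next compound is compound 4 `O=C1/C(=C/c2cccnc2)CN(S(=O)(=O)c2ccc(C(F)(F)F)cc2)C/C1=C\c1ccccc1C(F)(F)F`. It keeps the shared core of compound 3 and changes a single group on the sulfonyl-bearing aromatic ring: trifluoromethyl in place of nitro on an aromatic carbon. In words, this is trifluoromethyl in place of nitro on an aromatic carbon, or 4-nitrophenyl to 4-(trifluoromethyl)phenyl.

Among the measured compounds shown here, no measured pair makes exactly this swap, so the evidence is indirect. For the measured compounds named here, the one measured step involving the nitro group is a 1.3-fold higher number from compound 2 to compound 3 (0.10 log units; within the scatter), and it did not move the number beyond the scatter. Compound 1 already carries the 4-(trifluoromethyl)phenyl group, and in this assay compound 1 gives 11300 nM, which is in the same range as the others.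

No change beyond the scatter is therefore expected, and the estimated shift is a 1.2-fold lower number from compound 3 to compound 4 (0.08 log units; within the scatter). For compound 4 the expected value is 13000 nM, with an estimated range of 7500 nM to 21000 nM.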

Compound 4, half-maximal inhibitory concentration: 14300 nM
The estimate for compound 4 lay 1.1-fold (0.04 log units) below the measured number; low and high end bracket the measured number.
By their numbers in this assay, from the lowest: compounds 1, 2, 4 and 3 (each within the scatter of the next).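

In this assay, the place on the sulfonyl-bearing ring now holds hydrogen, nitro or trifluoromethyl, and the direct swap gives a 1.1-fold lower number from compound 3 to compound 4 (0.04 log units; within the scatter) while trifluoromethyl in place of hydrogen gives a 1.1-fold higher number from compound 2 to compound 4 (0.06 log units; within the scatter), so neither step separates the compounds. A different place also enters the picture: with trifluoromethyl already on the sulfonyl-bearing ring, trifluoromethyl in place of fluoro on the other aromatic ring gives a 1.3-fold higher number from compound 1 to compound 4 (0.10 log units; within the scatter), which likewise stays within the scatter. Together these steps show that, for these few groups, the number barely responds at either place, something the single nitro step could only hint at, and nothing available here accounts for how close the numbers stay.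

The compounds shown do not tell how an amine, a carboxylic acid or a longer chain such as butyl would read on the sulfonyl-bearing ring, so it remains open whether any group at this place can move the number beyond the scatter. They also leave open whether the same flat picture would hold with a change to the shared core, which all four compounds keep.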